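The source may report more compounds than this note shows. Statements on the series, on what has been measured and on what is new or still open speak of the compounds shown alone.

Compound 2 `CCC/C=C\C(=O)Nc1cc(Nc2nccc(-c3cn(C)c4ccccc34)n2)c(OC)cc1N(C)CCN(C)C` and compound 1 `COc1cc(N(C)CCN(C)C)c(NC(=O)/C=C\C(C)C)cc1Nc1nccc(-c2cn(C)c3ccccc23)n1` share one core and differ only in the chain on the amide. In a functional assay on A549 cells (Homo sapiens) for antiproliferative activity, read by MTT assay, with a stated time of 72 h (a higher number here means a weaker inhibitor, a lower number a stronger inhibitor), compound 1 gives 612 nM, and compound 2 gives 808 nM; the step of a 1.3-fold higher number from compound 1 to compound 2 (0.12 log units; within the scatter) keeps both within the scatter, so compound 2 holds the higher of the two numbers without being set apart from compound 1. Compound 3 `CCC/C=C\C(=O)Nc1cc(Nc2nccc(-c3cn(C)c4ccc(F)cc34)n2)c(OC)cc1N(C)CCN(C)C` differs from compound 2 by fluoro in place of hydrogen on an aromatic carbon. Among the compounds with values here, no measured step touches this ring, so nothing beyond the scatter is expected, and the step of a 1.0-fold lower number from compound 2 to compound 3 (0.00 log units; within the scatter) is estimated as flat. Compound 3 is therefore expected at 800 nM, between 350 nM and 1800 nM.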

Compound 3, half-maximal inhibitory concentration: 1030 nM
For compound 3 the middle estimate is 1.3-fold (0.11 log units) below the measured one; the measured number falls inside the stated range.
By their numbers in this assay, from the lowest: compounds 1, 2 and 3 (each within the scatter of the next).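

In this assay, within the data shown here, the change from 1-methyl-1H-indol-3-yl to 5-fluoro-1-methyl-1H-indol-3-yl gives the first reading on this ring, where the earlier step touched only the chain on the amide (a 1.3-fold higher number from compound 2 to compound 3 (0.11 log units; within the scatter)). Fluoro in place of hydrogen on this aromatic carbon is thus not told apart from hydrogen here. Nothing at hand offers an explanation for this result. The compounds shown leave open how methoxy, chloro or an amine would read on this carbon. They also leave open whether fluoro would read the same alongside the isopropyl chain of compound 1.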